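The compounds below may be only part of what the source reports. "The series", "measured", "known", "first", "only" and "open" are said of these compounds alone.

Measured so far in a functional assay on COLO 205 cells (Homo sapiens) for antiproliferative activity, read by sulforhodamine B assay, with a stated time of 72 h; on this read-out higher numbers stand for weaker inhibition and lower numbers for stronger inhibition:
- compound 1 `O=C1CS/C(=N/Nc2nncc3ccccc23)N1c1ccccc1`, 32 nM
- compound 2 `Cc1cc(NS(=O)(=O)c2ccc(Nc3nncc4ccccc34)cc2)no1`, 43 nM

Compound 2 holds the higher of the two numbers in this assay, but its nearest neighbour, compound 1, sits within the scatter of it, so the two cannot be ordered on these data. Compound 2 is the starting point for the next compound in the series, compound 3 `O=S(=O)(Nc1ccccn1)c1ccc(Nc2nncc3ccccc23)cc1`, which keeps the whole of compound 2 apart from one change: pyridin-2-yl in place of 5-methyl-1,2-oxazol-3-yl on a sulfonamide nitrogen. Cut one bond further out, the same change reads (5-methyl-1,2-oxazol-3-yl)amino to (pyridin-2-yl)amino.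

Going by the values given here, no step between two measured compounds is available here, so there is nothing measured to anchor the size of this change. The two measured compounds differ in several places at once and land within the scatter of each other, which gives no sign that changes of this kind move the read-out much. The step is therefore expected to be a 1.0-fold higher number from compound 2 to compound 3 (0.02 log units; within the scatter), that is, no shift beyond the scatter in either direction. Compound 3 is accordingly estimated at 45 nM in this assay, with a range from 15 nM to 150 nM.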

Compound 3, half-maximal inhibitory concentration: 44 nM
For compound 3 the middle estimate is 1.0-fold (0.01 log units) above the measured one; the range from low to high includes it.
By their numbers in this assay, from the lowest: compounds 1, 2 and 3 (each within the scatter of the next).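

In this assay the series now has its first step in a single place: the exchange of 5-methyl-1,2-oxazol-3-yl for pyridin-2-yl on a sulfonamide nitrogen is a 1.0-fold higher number from compound 2 to compound 3 (0.01 log units; within the scatter) and gives the position its first measured anchor. At this position, a five-membered aromatic ring with 2 hetero atoms and a six-membered aromatic ring with 1 hetero atom cannot be told apart on this read-out, even though the group entering has 1 hydrogen-bond acceptor and the group leaving has 2. No measurement at hand accounts for this outcome.

Going by these compounds, both groups seen on this nitrogen are aromatic rings, so it remains open whether a non-aromatic group such as a morpholine, a short alkyl chain or a chain ending in a carboxylic acid would also stay within the scatter. On these data alone, it is also open whether a methyl group or a chlorine atom on the pyridin-2-yl ring would shift the number beyond the scatter, and whether this flat step would hold on other cell lines.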